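The compounds below may be only part of what the source reports. "The series", "measured", "known", "first", "only" and "open" are said of these compounds alone.

Compound 3, `Cc1ccc(NC(=S)NC(=O)c2cn(-c3ccccc3)nc2-c2ccccc2)cc1`, is measured in a functional assay on MCF7 cells (Homo sapiens) for inhibition, read by CCK-8 assay, with a stated time of 48 h (on this read-out higher numbers stand for weaker inhibition and lower numbers for stronger inhibition), and gives 5900 nM. Its two neighbours are compound 1, `O=C(NC(=S)Nc1ccc(F)cc1)c1cn(-c2ccccc2)nc1-c1ccccc1`, which in this assay gives 6820 nM, and compound 2, `Cc1ccc(NC(=S)NC(=O)c2cn(-c3ccccc3)nc2-c2ccc(C)cc2)cc1`, which gives 5660 nM. All three numbers sit close together: the step of a 1.2-fold lower number from compound 1 to compound 3 (0.06 log units; within the scatter) and the step of a 1.0-fold higher number from compound 2 to compound 3 (0.02 log units; within the scatter) are both within the scatter, so compound 3 stands among three numbers that cannot be told apart.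

Compound 4, `O=C(NC(=S)Nc1ccc(Cl)cc1)c1cn(-c2ccccc2)nc1-c1ccccc1`, has not yet been measured in this assay. It differs from compound 3 by chloro in place of methyl on an aromatic carbon. Among the measured compounds shown here, the step that bears on this change is the one from compound 1 to compound 3, a 1.2-fold lower number from compound 1 to compound 3 (0.06 log units; within the scatter), in which a fluoro at this same place gave way to methyl without a shift beyond the scatter. A chloro at that place is therefore expected to behave alike, and no step beyond the scatter is expected in this assay for the change no change at the digits printed from compound 3 to compound 4 (within the scatter). Compound 4 is therefore estimated at 5900 nM, with a range from 3000 nM to 12000 nM.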

Compound 4, half-maximal inhibitory concentration: 6230 nM
Compound 4: the middle estimate sits 1.1-fold (0.02 log units) below what was measured; measured number inside the range.
By their numbers in this assay, from the lowest: compounds 2, 3, 4 and 1 (each within the scatter of the next).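

In this assay, chloro in place of methyl gives a 1.1-fold higher number from compound 3 to compound 4 (0.02 log units; within the scatter) and chloro in place of fluoro gives a 1.1-fold lower number from compound 1 to compound 4 (0.04 log units; within the scatter), so neither change moves the number beyond the scatter. Earlier, only fluoro and methyl could be compared at this position; a third group, chloro, now reads the same, which widens the set of groups on this ring that cannot be told apart. Nothing measured here explains why these groups read alike.

Going by these compounds, it remains open whether this position would stay as unresponsive with a quite different group there, such as an amine, a carboxylic acid or a longer chain. On these data alone, it is also open whether chloro would read the same on the core of compound 2, which carries a second methyl.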